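Methyl in Place of Methoxy on the Shared Core

The source may report more compounds than this note shows. Statements on the series, on what has been measured and on what is new or still open speak of the compounds shown alone.

Compound 1 `O=Cc1coc(C(=O)CCCCCCc2ccccc2)n1`: 1510 nM
Compound 2 `COc1coc(C(=O)CCCCCCc2ccccc2)n1`: > 10000 nM

Of the compounds shown here, two have been measured in an assay on HEK-293T cells for inhibition of diacylglycerol lipase-alpha (Homo sapiens), read by colorimetric assay; on this read-out higher numbers stand for weaker inhibition and lower numbers for stronger inhibition. Compound 1 gives 1510 nM. Compound 2 reaches only the limit of the assay, > 10000 nM, so it has no number of its own. Compound 2 therefore sits at the limit of > 10000 nM in this assay, at which 1 of the 2 values shown sits, the weaker end of what has been seen. Going by the values given here, the one step that is known, an at least 6.6-fold higher number from compound 1 to compound 2 (0.82 log units; beyond the scatter), runs in the direction of weaker inhibition.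

Compound 3 `Cc1coc(C(=O)CCCCCCc2ccccc2)n1` is not yet measured. It differs from compound 2 by methyl in place of methoxy on an aromatic carbon. Among the compounds with values here, no measured pair shows a change of methoxy to methyl, so the step from compound 2 to compound 3 can only be judged from where compound 2 stands. Compound 3 is expected to stay weak, with a step of an at least 1.2-fold lower number from compound 2 to compound 3 (0.09 log units; that floor lies within the scatter) that may not exceed the scatter. The estimate for compound 3 in this assay is 8000 nM, within a range from 2000 nM to 30000 nM.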

Compound 3, half-maximal inhibitory concentration: > 10000 nM
Compound 3 ended at the assay's limit; the forecaster's own chance of this, stated with the estimate: 45%; middle value at least 1.2-fold (0.09 log units) away from the limit.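

In this assay compound 3 also gives only a limit of the assay, > 10000 nM, and so joins compound 2 at the weak end of the series: the limit of > 10000 nM in this assay, at which 2 of the 3 values shown sit.

Methyl in place of formyl on this aromatic carbon gives an at least 6.6-fold higher number from compound 1 to compound 3 (0.82 log units; beyond the scatter), so among the three groups shown here, formyl alone gives a value short of the limit, and the loss seen with methoxy is not confined to that one replacement. The step between compound 2 and compound 3 cannot be read, as both values are limits.

Going by these compounds, whether methoxy and methyl differ at all therefore stays open. So does whether any other group on this carbon, such as a carboxylic acid, a methyl ester, an amide or an amine, would match or pass the formyl group of compound 1.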